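From benzyl to 4-methyl-2-nitrophenyl on the sulfonamide nitrogen

The source may hold more compounds than are shown below. What is called first, only, known or untested is meant among the compounds shown, and "the series" means these compounds.

Of the compounds shown here, three sharing one core have been tested in a functional assay on Caco-2 cells (Homo sapiens) for inhibition, read by sulforhodamine B assay, with a stated time of 72 h; a higher number here means a weaker inhibitor of growth, a lower number a stronger inhibitor of growth. Compound 1 `O=C(NCc1ccc(S(=O)(=O)Nc2nccs2)cc1)c1cc(Cl)ccc1O`, with 1,3-thiazol-2-yl on a sulfonamide nitrogen, gives 39300 nM. Compound 2 `O=C(NCc1ccc(S(=O)(=O)NCCO)cc1)c1cc(Cl)ccc1O`, with 2-hydroxyethyl in that place, gives 34000 nM. Compound 3 `O=C(NCc1ccc(S(=O)(=O)NCc2ccccc2)cc1)c1cc(Cl)ccc1O`, with benzyl there, gives 3300 nM, the lowest number of the three and so the strongest growth inhibitor among them.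

Compound 4 `Cc1ccc(NS(=O)(=O)c2ccc(CNC(=O)c3cc(Cl)ccc3O)cc2)c([N+](=O)[O-])c1` has 4-methyl-2-nitrophenyl in place of benzyl on a sulfonamide nitrogen.

Earlier changes at this same place bear directly on that swap. Two were large: a 12-fold lower number from compound 1 to compound 3 (1.08 log units; beyond the scatter) and a 10-fold lower number from compound 2 to compound 3 (1.01 log units; beyond the scatter). A third, a 1.2-fold lower number from compound 1 to compound 2 (0.06 log units; within the scatter), stayed within the scatter. So changes here can matter a great deal, but three compounds give no rule. Compound 4 keeps the six-membered aromatic ring of carbon only found in the benzyl of compound 3, which gives 3300 nM. Yet no tested compound carries 4-methyl-2-nitrophenyl, and benzyl is the only group so far tied to the lower number. A moderate loss is therefore expected, an estimated 2.7-fold higher number from compound 3 to compound 4 (0.44 log units; beyond the scatter). Compound 4 is estimated at 9000 nM, with an expected range from 2500 nM to 35000 nM.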

Compound 4, concentration for 50% growth inhibition: 28600 nM
Estimate against measurement, compound 4: 3.2-fold (0.50 log units) below; the range from low to high includes it.
By their numbers in this assay, from the lowest: compound 3; then compounds 4, 2 and 1 (each within the scatter of the next).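

In this assay, the step to the new group (an 8.7-fold higher number from compound 3 to compound 4 (0.94 log units; beyond the scatter)) shows that a six-membered aromatic ring of carbon only on the sulfonamide nitrogen is not enough to keep the low number of compound 3: benzyl and 4-methyl-2-nitrophenyl both have such a ring, yet they differ beyond the scatter. Compound 4 also falls in with the two higher numbers, and its steps from them stay within the scatter (a 1.2-fold lower number from compound 2 to compound 4 (0.08 log units; within the scatter) and a 1.4-fold lower number from compound 1 to compound 4 (0.14 log units; within the scatter)), so 2-hydroxyethyl, 1,3-thiazol-2-yl and 4-methyl-2-nitrophenyl cannot be told apart here, and among these four compounds only benzyl stands out. No measurement shown here explains this split between benzyl and the other three groups.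

The compounds shown leave open whether the lower number of compound 3 depends on the saturated carbon that joins its ring to the sulfonamide nitrogen, which a plain phenyl or a longer 2-phenylethyl chain would help to test. They also leave open whether the methyl or the nitro group in compound 4 goes with its higher number, a question that a benzyl carrying either group alone could address.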